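This account rests on a few compounds, and the source may have more. Where it says the series, first, only, none or still open, it means among the compounds named here.

Compound 1 `c1ccc(-c2n[nH]cc2N2CCNCC2)cc1` is the starting point of this small series. In an assay on isolated protein for binding affinity to 5-hydroxytryptamine receptor 3A (Homo sapiens) (on this read-out lower numbers stand for stronger inhibition and higher numbers for weaker inhibition), compound 1 gives only a limit, > 10000 nM. Compound 2 `Clc1ccc(-c2n[nH]cc2N2CCNCC2)cc1` carries chloro in place of hydrogen on an aromatic carbon, and in this assay compound 2 gives 1790 nM. The step of an at least 5.5-fold lower number from compound 1 to compound 2 (0.74 log units; beyond the scatter) is the single measured step among these compounds. Compound 2 therefore holds the only number shown in this assay, the other value being a limit, (the limit of > 10000 nM in this assay, at which 1 of the 2 values shown sits).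

Compound 3 `Fc1ccc(-c2n[nH]cc2N2CCNCC2)cc1` has not yet been measured. Its change from compound 2 is fluoro in place of chloro on an aromatic carbon. For the measured compounds named here, no measured step exchanges one halogen for another, so only an at least 5.5-fold lower number from compound 1 to compound 2 (0.74 log units; beyond the scatter) bears on it, and only loosely: it shows that the group on this aromatic carbon, para to a large group, changes the number by a large margin when chloro replaces hydrogen. Fluoro is neither of those, so a modest weakening from compound 2 is expected, with the limit a real possibility. Compound 3 is estimated at 4000 nM in this assay, with a range from 1500 nM to 10000 nM, which amounts to an expected step of a 2.2-fold higher number from compound 2 to compound 3 (0.35 log units; beyond the scatter).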

Compound 3, inhibition constant: > 10000 nM
Compound 3: only a limit was reported; the forecaster's own chance of this, stated with the estimate: 25%; middle value at least 2.5-fold (0.39 log units) from the limit.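

Exchanging chloro for fluoro on this aromatic carbon, para to a large group, gives an at least 5.5-fold higher number from compound 2 to compound 3 (0.74 log units; beyond the scatter) in this assay, so the number here depends on which halogen is present and not merely on a halogen being there. Among the compounds shown, only chloro at this position gives a number rather than a limit, and fluoro has not been shown to differ from hydrogen: both compound 1 and compound 3 are reported only as limits, so the step between them cannot be read. The whole reading of this position therefore rests on the single number of compound 2, with the rest of the small series held at one limit: the limit of > 10000 nM in this assay, at which 2 of the 3 values shown sit.

Going by these compounds, it remains open whether bromo, methyl, trifluoromethyl or methoxy on this carbon would give a number at all, and whether any of them would give a lower one than chloro does. On these data alone, how far compound 1 and compound 3 lie beyond their limits also stays open, and with it any order between the two.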